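The source may hold more compounds than are shown below. What is called first, only, known or untested is meant among the compounds shown, and "the series" means these compounds.

Compound 1 `O=C(N/N=C/c1ccccc1)c1cccnc1` is the parent of this small set. In an ADME assay on MT4 cells (Homo sapiens) for cytotoxicity, read by MTT assay, with a stated time of 4 days (a higher number here means that more compound is tolerated, a lower number that less compound is tolerated), compound 1 gives > 125 ug/mL, which is a limit of the assay and not a number. Compound 2 `O=C(N/N=C/c1cccc(Cl)c1)c1cccnc1` carries chloro in place of hydrogen on an aromatic carbon, and in this assay compound 2 gives 62 ug/mL. Going by the values given here, the one measured step, an at least 2.0-fold lower number from compound 1 to compound 2 (0.30 log units; that floor lies within the scatter), cannot be sized exactly because compound 1 sits at the limit of > 125 ug/mL in this assay, at which 1 of the 2 values shown sits, so it may be no larger than the usual scatter.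

Compound 3 `O=C(N/N=C/c1ccc([N+](=O)[O-])cc1)c1cccnc1` differs from compound 1 by nitro in place of hydrogen on an aromatic carbon. Among the compounds with values here, the only step that bears on this change is an at least 2.0-fold lower number from compound 1 to compound 2 (0.30 log units; that floor lies within the scatter), a substitution on the same ring whose floor lies within the scatter. On that basis a small drop in tolerated concentration, or none beyond the scatter, is expected for compound 3 in this assay, with a fair chance that only a limit is returned again. Compound 3 is therefore expected to give about 80 ug/mL in this assay, within a range of 30 ug/mL to 125 ug/mL. That expectation corresponds to an estimated step of an at least 1.5-fold lower number from compound 1 to compound 3 (0.19 log units; that floor lies within the scatter).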

Compound 3, half-maximal cytotoxic concentration: 0.1 ug/mL
The estimate for compound 3 lay 800-fold (2.90 log units) above the measured number, outside the stated range (below it).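

In this assay, a single nitro in place of hydrogen on an aromatic carbon, para to a large group, gives an at least 1200-fold lower number from compound 1 to compound 3 (3.09 log units; beyond the scatter), so one substitution on this six-membered aromatic ring of carbon only is enough to change the tolerated concentration far beyond the scatter. The earlier step, an at least 2.0-fold lower number from compound 1 to compound 2 (0.30 log units; that floor lies within the scatter), could not show this, since its floor lay within the scatter and left open whether substitution on this ring mattered at all in this assay. The new step is still only a floor, and its true size cannot be read, because the value of compound 1 is a limit of the assay and not a number: the limit of > 125 ug/mL in this assay, at which 1 of the 3 values shown sits.

The compounds shown leave open whether the change follows the nitro group itself or its place, para to a large group, since nitro appears at no other place and no other group appears at this one. They also leave open what an amine or a carboxylic acid on the same aromatic carbon would give in this assay, and so whether compound 3 stands alone or belongs to a wider pattern.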